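Methoxy in place of methylamino at a carbonyl carbon

The compounds below may be only part of what the source reports. "The series", "measured", "known", "first", "only" and "open" are said of these compounds alone.

Measured compounds:
Compound 1, `N#Cc1c(N)nc(SCc2nc3ccccc3[nH]2)c(C#N)c1-c1ccc(OCC2CC2)cc1`: 21%
Compound 2, `N#Cc1c(N)nc(SCn2cncn2)c(C#N)c1-c1ccc(OCC2CC2)cc1`: 12%
Compound 3, `CNC(=O)CSc1nc(N)c(C#N)c(-c2ccc(OCC3CC3)cc2)c1C#N`: 14%

In an assay on CHO cells for displacement of a labelled ligand from adenosine receptor A1 (Homo sapiens), read by scintillation counting, with a stated time of 90 min, tested at 1 uM (on this read-out higher numbers stand for more inhibition at the one concentration tested (going by the name of the read-out) and lower numbers for less inhibition), compound 3 stands second highest of the three numbers. Its nearest neighbour is compound 2, with the step of a number 2 percentage points higher from compound 2 to compound 3 (within the scatter); the furthest is compound 1, with the step of a number 7 percentage points lower from compound 1 to compound 3 (within the scatter). The third measured step, a number 9 percentage points lower from compound 1 to compound 2 (within the scatter), is likewise within the scatter, so the three compounds cannot be ordered on these numbers.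

Compound 4, `COC(=O)CSc1nc(N)c(C#N)c(-c2ccc(OCC3CC3)cc2)c1C#N`, differs from compound 3 in one place: methoxy in place of methylamino on a carbonyl carbon. All three measured steps change the group on the saturated chain carbon bound to a sulfur, not the carbonyl carbon, so none of them tests this exact change. What they show is that exchanging the whole side group, from 1H-benzimidazol-2-yl through 1H-1,2,4-triazol-1-yl to methylcarbamoyl, moved the inhibition only within the scatter. A smaller exchange inside the methylcarbamoyl group is therefore expected to give a step in this assay of no clear size in either direction, namely no change at the digits printed from compound 3 to compound 4 (within the scatter).

Compound 4 is accordingly estimated at 14%, within a range from 4% to 26%.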

Compound 4, a percentage reported as inhibition, at one concentration (the size of the read-out at that concentration, not a potency): 23%
Beside the measured number, compound 4's estimate is 9 percentage points below it; the measured number falls inside the stated range.
By their numbers in this assay, from the lowest: compounds 2, 3, 1 and 4 (each within the scatter of the next, the first and the last beyond it).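

In this assay, the exchange at this carbonyl carbon gives a number 9 percentage points higher from compound 3 to compound 4 (within the scatter). Methoxy in place of methylamino removes a hydrogen-bond donor and adds a hydrogen-bond acceptor, yet this single change cannot be told apart from no change at all. Against the other side groups on the saturated chain carbon bound to a sulfur, methoxycarbonyl gives a number 11 percentage points higher from compound 2 to compound 4 (beyond the scatter), the only step shown that lies beyond the scatter, though it is modest, while a number 2 percentage points higher from compound 1 to compound 4 (within the scatter) does not separate the two compounds, so the side group has at most a small, partly visible effect on this read-out. No measurement shown gives a reason for any of these numbers.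

The compounds shown leave open what other groups on this carbonyl carbon would give, such as a hydroxyl, which would make a carboxylic acid, a longer chain such as ethoxy, or a dimethylamino group. As far as these compounds go, with all four compounds tested at a single concentration against one receptor, it also remains open whether the modest step seen with methoxycarbonyl would hold up as a real difference in potency.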